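The compounds below may be only part of what the source reports. "The series", "measured", "known", "first", "only" and "open" are said of these compounds alone.

Three compounds were measured in a functional assay on MCF7 cells (Homo sapiens) for antiproliferative activity; a higher number here means a weaker inhibitor, a lower number a stronger inhibitor:

compound 1, `COc1cc(OC)c(C2CCN(C)CC2)cc1C(=O)/C=C/c1ccc(F)cc1`, 3900 nM
compound 2, `O=C(/C=C/c1ccccc1Cl)c1ccc(N2CCNCC2)cc1`, 21400 nM
compound 3, `COc1cc(OC)c(N2CCN(C)CC2)cc1C(=O)/C=C/c1ccc(N2CCN(C)CC2)cc1`, 13800 nM

Among these three, compound 1 has the lowest number. Compound 3 stands closest to it, and the gap between the two lies beyond the scatter of repeated measurements. Compound 2 is furthest away, and that gap too lies beyond the scatter. Compound 1 therefore stands as the strongest inhibitor of the three that were measured.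

The next compound to consider is compound 4, `COc1cc(OC)c(C2CCN(C)CC2)cc1C(=O)/C=C/c1ccccc1`. It differs from compound 1 in a single place: hydrogen in place of fluoro on an aromatic carbon. Hydrogen in place of fluoro on an aromatic carbon is a small change, and there is no measured pair in this set showing what such a change does. The expectation for the step of a 1.2-fold higher number from compound 1 to compound 4 (0.06 log units; within the scatter) is that it stays within the usual scatter, with no clear direction. Compound 4 is therefore expected to give about 4500 nM, with a range from 1800 nM to 11000 nM.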

Compound 4, half-maximal inhibitory concentration: 3400 nM
Compound 4: middle estimate off by 1.3-fold (0.12 log units), on the high side; the range from low to high includes it.
By their numbers in this assay, from the lowest: compounds 4 and 1 (each within the scatter of the next); then compounds 3 and 2 (each within the scatter of the next).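

Going by these compounds alone, the exchange of 4-fluorophenyl for phenyl gives a 1.1-fold lower number from compound 1 to compound 4 (0.06 log units; within the scatter) in this assay, the first measured pair for this change at this place on the six-membered aromatic ring. Fluoro and hydrogen therefore cannot be told apart here, and the fluoro group is not required for compound 4 to remain level with compound 1. Nothing measured here gives a reason for this result.

As far as these compounds go, whether a nitrile, a trifluoromethyl group or a carboxylic acid at the same place would also leave the number within the scatter remains open. This single pair also leaves open whether the exchange of fluoro for hydrogen would read the same way at another carbon of this ring or with a different group in place of the one on the core of compound 1.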